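The source may hold more compounds than are shown below. What is called first, only, known or untested is meant among the compounds shown, and "the series" means these compounds.

Among the measured compounds shown here, in a toxicity assay on THP-1 cells (Homo sapiens) for inhibition (a higher number here means that more compound is tolerated, a lower number that less compound is tolerated), only two compounds have been measured so far. Compound 1 `COc1ccc(-c2cnc(NC(=O)c3ccc(F)cc3)n2Cc2ccccc2)cc1` gives > 100000 nM, which is a limit of the assay and not a number. Compound 2 `Cn1c(-c2ccccc2F)cnc1NC(=O)c1ccc(F)cc1` gives > 100000 nM, which is also a limit and not a number. The position of compound 2 is therefore defined only by the limit of > 100000 nM in this assay, at which 2 of the 2 values shown sit.

Compound 3 `Cc1ccccc1-c1cnc(NC(=O)c2ccc(F)cc2)n1C` has yet to be measured. It departs from compound 2 by a single exchange, methyl in place of fluoro on an aromatic carbon, ortho to a large group: methyl in place of fluoro on an aromatic carbon. Read one bond further out, this is 2-fluorophenyl to 2-methylphenyl. For the measured compounds named here, no measured pair shows what such an exchange does in this assay, so no direction is favoured and no change beyond the usual scatter is expected. This expectation starts from compound 2, whose limit is > 100000 nM. The expected step of a number no higher from compound 2 to compound 3 (the limit leaves the size open) is accordingly small. Compound 3 is estimated at 100000 nM, with an expected range of 40000 nM to 200000 nM, and the assay may again report only a limit.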

Compound 3, half-maximal cytotoxic concentration: > 50000 nM
Compound 3 was reported as a limit; the forecaster's own chance of this, stated with the estimate: 85%; the middle value is on the limit's open side.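

In this assay compound 3 gives > 50000 nM, which is a limit and not a number. Compound 2 also stands only at a limit, so no step can be read from the pair of compound 2 and compound 3. The compounds shown leave open what methyl in place of fluoro does in this assay, and at what concentration any of them becomes toxic to these cells.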